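Turning the Ester Around: What to Expect for Compound 3

The compounds below may be only part of what the source reports. "The series", "measured", "known", "first", "only" and "open" are said of these compounds alone.

Measured so far:
compound 1 `CCCOC(=O)C1=CCCCC1S(=O)(=O)Cc1ccc(F)cc1Cl`: 14 nM
compound 2 `CCCCOC(=O)C1=CCCCC1S(=O)(=O)Cc1ccc(F)cc1Cl`: 103 nM

In a functional assay on RAW264.7 cells (Mus musculus), read by fluorescence (a higher number here means a weaker inhibitor, a lower number a stronger inhibitor), compound 1 gives 14 nM, while compound 2 gives 103 nM. Compound 2 therefore stands highest of the two numbers, and its nearest neighbour is compound 1; the step of a 7.4-fold higher number from compound 1 to compound 2 (0.87 log units; beyond the scatter) lies beyond the scatter, so adding a methyl on the saturated chain three bonds from the ester oxygen weakened inhibition in this assay.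

Compound 3 `CC(=O)OCC1=CCCCC1S(=O)(=O)Cc1ccc(F)cc1Cl` is not yet measured. It differs from compound 2 in one place: acetoxymethyl in place of butoxycarbonyl on a double-bonded ring carbon. Among the measured compounds shown here, the only measured step touches the same region, the ester on the double-bonded ring carbon, and shows that enlarging it raised the number. For the measured compounds named here, compound 3 carries the smaller group, but the ester is also turned around, which no measured pair covers, so the expectation is broad. Compound 3 is expected to give 60 nM, with a range from 12 nM to 300 nM. This would mean an expected step of a 1.7-fold lower number from compound 2 to compound 3 (0.23 log units; within the scatter), a modest lowering that stays uncertain.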

Compound 3, half-maximal inhibitory concentration: > 10000 nM
Compound 3: a limit, no number; the forecaster's own chance of this, stated with the estimate: 5%; at least 160-fold (2.22 log units) between middle value and limit.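

In this assay compound 3 gives no number, only a limit of the assay: the limit of > 10000 nM in this assay, at which 1 of the 3 values shown sits. Replacing butoxycarbonyl with acetoxymethyl on the double-bonded ring carbon produces an at least 97-fold higher number from compound 2 to compound 3 (1.98 log units; beyond the scatter), and replacing propoxycarbonyl with the same group produces an at least 710-fold higher number from compound 1 to compound 3 (2.85 log units; beyond the scatter), so both large steps show that activity in this series depends heavily on which ester group sits at this position. The earlier step, a 7.4-fold higher number from compound 1 to compound 2 (0.87 log units; beyond the scatter), suggested that a larger group gives a higher number, but compound 3 goes against that pattern: acetoxymethyl has fewer heavy atoms than either group it replaces, and the number still rises much further.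

Turning the ester around and shortening its far end happen together in compound 3, and the compounds shown cannot separate these two changes. Also open, from the compounds shown here alone, is how a longer turned-around ester such as butanoyloxymethyl, or a carboxylic acid or an amide on the same ring carbon, would behave in this assay.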